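Hydrazone series against a corticotropin-releasing factor receptor

The compounds below may be only part of what the source reports. "The series", "measured", "known", "first", "only" and "open" are said of these compounds alone.

Compound 1 `CC(=O)/C(=N\Nc1ccccc1)Oc1cccc(Cl)c1`, compound 2 `CC(=O)/C(=N\Nc1ccccc1C(F)(F)F)Oc1cccc(Cl)c1` and compound 3 `CC(=O)/C(=N\c1ccccc1Cl)NNc1ccccc1C(F)(F)F` were tested in an assay on isolated protein for binding affinity to corticotropin-releasing factor receptor 1 (Homo sapiens); a lower number here means a stronger inhibitor, a higher number a weaker inhibitor. For compound 1 only a limit of the assay is recorded, > 10000 nM. For compound 2 the result is likewise a limit, > 10000 nM. For compound 3 the result is again a limit, > 10000 nM. The difference between the core of compound 2 and the core of compound 3 is not broken down here.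

Compound 2 and compound 1 differ by hydrogen in place of trifluoromethyl on an aromatic carbon. The resulting step that the two limits leave unreadable from compound 2 to compound 1 cannot be sized, since (the limit of > 10000 nM in this assay, at which 3 of the 3 values shown sit).

Compound 4 `CC(=O)/C(=N\c1ccccc1Cl)NNc1ccccc1` is not yet measured. It differs from compound 3 by hydrogen in place of trifluoromethyl on an aromatic carbon, the same change as between compound 2 and compound 1, with the same surroundings at the place of change. With both parents of that change sitting at the limit, the step from compound 3 to compound 4 is expected to be a step that the limit leaves unreadable from compound 3 to compound 4, which would leave compound 4 at the limit too. The estimate for compound 4 in this assay is therefore 15000 nM, with a range from 5000 nM to 50000 nM.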

Compound 4, inhibition constant: > 10000 nM
Compound 4 gave a limit, no number; the forecaster's own chance of this, stated with the estimate: 85%; the middle value is on the limit's open side.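

In this assay compound 4 gives > 10000 nM, a limit and not a number. No step from compound 3 to compound 4 can be read, because both compounds end at a limit: the limit of > 10000 nM in this assay, at which 4 of the 4 values shown sit.

The compounds shown leave open what size, if any, the exchange of trifluoromethyl for hydrogen has in this assay, and whether any member of this series gives a readable value.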